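Thiosemicarbazones of a Monoterpene Amine in Renal Carcinoma Cells

This account rests on a few compounds, and the source may have more. Where it says the series, first, only, none or still open, it means among the compounds named here.

The compounds share the core of compound 1 `CC1=CC[C@H](C(C)(C)NC(=S)NN)CC1`, which carries no aryl group on the hydrazine end. In a functional assay on 786-0 cells (Homo sapiens) for inhibition, read by sulforhodamine B assay, with a stated time of 48 h (a higher number here means a weaker inhibitor of growth, a lower number a stronger inhibitor of growth), compound 1 gives > 100000 nM, a limit of the assay rather than a number. Compound 2 `CC1=CC[C@H](C(C)(C)NC(=S)N/N=C/c2ccc(O)cc2)CC1` adds a 4-hydroxyphenyl group on the carbon with a double bond to nitrogen, and in this assay compound 2 gives > 100000 nM, again a limit. Compound 3 `CC1=CC[C@H](C(C)(C)NC(=S)N/N=C/c2ccc(N(C)C)cc2)CC1` carries a dimethylamino group in place of the hydroxy group, and in this assay compound 3 gives > 100000 nM, also a limit. The step that the two limits leave unreadable from compound 2 to compound 3 therefore cannot be read. Among the compounds with values here, every value so far sits at the limit of > 100000 nM in this assay, at which 3 of the 3 values shown sit, so compound 2 stands at that limit with no number of its own.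

Compound 4 `CC1=CC[C@H](C(C)(C)NC(=S)N/N=C/c2cccc(Cl)c2)CC1` differs from compound 2 by 3-chlorophenyl in place of 4-hydroxyphenyl on a carbon with a double bond to nitrogen. Within the data shown here, only one measured step touches the aryl group, and a step that the two limits leave unreadable from compound 2 to compound 3 shows no readable size, so nothing measured indicates which way the change to 3-chlorophenyl moves the read-out. Given that compound 2 gives > 100000 nM, the most likely outcome for compound 4 is expected to be another limit, and the step of a number no higher from compound 2 to compound 4 (the limit leaves the size open) is expected to be nothing readable. Compound 4 is therefore estimated at 100000 nM, with a range of 25000 nM to 400000 nM.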

Compound 4, concentration for total growth inhibition: 26900 nM
For compound 4 the middle estimate is 3.7-fold (0.57 log units) above the measured one; the range from low to high includes it.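

In this assay, within the data shown here, compound 4 gives 26900 nM, the first value that is a number rather than a limit, which shows that the aryl group on the carbon with a double bond to nitrogen can change the read-out. Among these compounds, replacing 4-hydroxyphenyl with 3-chlorophenyl gives an at least 3.7-fold lower number from compound 2 to compound 4 (0.57 log units; beyond the scatter), whereas the earlier steps cannot be read. This size is only a lower bound, since compound 2 has no number of its own and sits with the other compounds at the limit of the assay: the limit of > 100000 nM in this assay, at which 3 of the 4 values shown sit.

The change also swaps hydroxy for chlorine and alters the place of the substituent on the aromatic ring, so the compounds shown leave open whether the identity of the substituent, its place, or both account for the step. They also leave open how far the read-out would follow a bromine, a methoxy group or a nitrile on that ring, and whether a second chlorine would lower the number further.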